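Thiazolidinedione series: nitrogen substituent on the ring amide

A few compounds are considered here, and "the series" means these few. Any claim that something is new, unique, unknown or untested is made for them only; others in the source may bear on it.

Measured compounds:
compound 1 `COc1cc(-c2nc3cc(/C=C4\SC(=O)NC4=O)ccc3[nH]2)cc(OC)c1OC` — 6830 nM
compound 2 `COc1cc(-c2nc3cc(/C=C4\SC(=O)N(CC(=O)N5CCCCC5)C4=O)ccc3[nH]2)cc(OC)c1OC` — 34900 nM

In a functional assay on MDA-MB-231 cells (Homo sapiens) for inhibition, read by MTT assay, with a stated time of 48 h (on this read-out higher numbers stand for weaker inhibition and lower numbers for stronger inhibition), compound 1 gives 6830 nM. Compound 2 carries a ((piperidin-1-yl)carbonyl)methyl group on the ring amide nitrogen that is unsubstituted in compound 1, and in this assay compound 2 gives 34900 nM. The step of a 5.1-fold higher number from compound 1 to compound 2 (0.71 log units; beyond the scatter) shows that substituting the ring amide nitrogen weakened inhibition beyond the scatter. Going by the values given here, of the two numbers in hand, compound 2 stands as the higher one, with compound 1 as its only neighbour.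

Compound 3 `COc1cc(-c2nc3cc(/C=C4\SC(=O)N(Cc5ccccc5)C4=O)ccc3[nH]2)cc(OC)c1OC` keeps the substituted ring amide nitrogen but changes what hangs on it: phenyl in place of (piperidin-1-yl)carbonyl on a saturated chain carbon bound to an amide-type nitrogen in a ring. Among the compounds with values here, no measured step bears directly on swapping one nitrogen substituent for another; the only step in hand, a 5.1-fold higher number from compound 1 to compound 2 (0.71 log units; beyond the scatter), concerns adding a substituent to that nitrogen, not exchanging it. Since both compound 2 and compound 3 carry a substituent there, compound 3 is expected to sit nearer to compound 2 than to compound 1, and the step of a 1.7-fold lower number from compound 2 to compound 3 (0.24 log units; within the scatter) is expected to stay within or near the scatter. Compound 3 is therefore estimated at 20000 nM, within a range of 6000 nM to 60000 nM.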

Compound 3, half-maximal inhibitory concentration: 2290 nM
Beside the measured number, compound 3's estimate is 8.7-fold (0.94 log units) above it, outside the stated range (below it).
By their numbers in this assay, from the lowest: compound 3; then compound 1; then compound 2.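

Substituting the ring amide nitrogen does not by itself weaken inhibition: in this assay, benzyl in place of hydrogen moves the result the opposite way to the earlier change (a 3.0-fold lower number from compound 1 to compound 3 (0.47 log units; beyond the scatter)), so compound 3 is the strongest of the three, with its steps to both others beyond the scatter. The outcome at this position therefore depends on what the nitrogen carries, not merely on whether it is substituted. Phenyl in place of (piperidin-1-yl)carbonyl on a saturated chain carbon bound to an amide-type nitrogen in a ring gives the largest step so far (a 15-fold lower number from compound 2 to compound 3 (1.18 log units; beyond the scatter)), although no available measurement accounts for the difference.

The compounds shown leave open whether the improvement over the unsubstituted nitrogen extends to a phenethyl chain, or to a benzyl group carrying chlorine or methoxy on its ring. They also leave open whether the weaker result for compound 2 follows the carbonyl or the piperidine ring, a question that a carboxylic acid or a dimethylamide on the same chain carbon could help to separate.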